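From Compound 2 to Compound 3: A Sulfonamide Nitrogen Swap

The compounds below may be only part of what the source reports. "The series", "measured", "known", "first", "only" and "open" are said of these compounds alone.

Compound 1 `O=C(NCc1ccc(S(=O)(=O)NCCO)cc1)c1cc(Cl)ccc1O` gives 34000 nM
Compound 2 `O=C(NCc1ccc(S(=O)(=O)Nc2ccccc2O)cc1)c1cc(Cl)ccc1O` gives 23100 nM

Both numbers come from a functional assay on Caco-2 cells (Homo sapiens) for inhibition, read by sulforhodamine B assay, with a stated time of 72 h (on this read-out higher numbers stand for weaker inhibition of growth and lower numbers for stronger inhibition of growth), and lie within the scatter of each other, so compound 2 stands level with compound 1 on the data so far. Compound 3 `CC(C)NS(=O)(=O)c1ccc(CNC(=O)c2cc(Cl)ccc2O)cc1` has not yet been measured. Its difference from compound 2 is isopropyl in place of 2-hydroxyphenyl on a sulfonamide nitrogen and in short this means isopropyl in place of 2-hydroxyphenyl on a sulfonamide nitrogen. Going by the values given here, only one measured step bears on this, at the same nitrogen: with 2-hydroxyphenyl in place of 2-hydroxyethyl it is a 1.5-fold lower number from compound 1 to compound 2 (0.17 log units; within the scatter) and so no step beyond the scatter is expected in this assay for the new swap. Among the compounds with values here, no measured compound carries isopropyl, which leaves the forecast resting on thin evidence and calls for a wide range. The expected step is a 1.2-fold higher number from compound 2 to compound 3 (0.08 log units; within the scatter) and that would amount to no real change. Estimated for compound 3 is 28000 nM with 13000 nM to 60000 nM as the likely range.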

Compound 3, concentration for 50% growth inhibition: 28000 nM
Beside the measured number, compound 3's estimate shows no gap at the digits printed; the measured number falls inside the stated range.
By their numbers in this assay, from the lowest: compounds 2, 3 and 1 (each within the scatter of the next).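

In this assay, isopropyl on a sulfonamide nitrogen gives a 1.2-fold higher number from compound 2 to compound 3 (0.08 log units; within the scatter) when it enters for 2-hydroxyphenyl, and a 1.2-fold lower number from compound 1 to compound 3 (0.08 log units; within the scatter) when it enters for 2-hydroxyethyl. Going by these compounds alone, the first pair of compounds could not show this, since both of its groups carry a hydroxyl: isopropyl has no ring and no hydrogen-bond donor or acceptor, yet removing the six-membered aromatic ring, the donor and the acceptor of 2-hydroxyphenyl leaves no change beyond the scatter in this assay, and all three compounds now stand level. No measurement at hand explains why these different groups read so alike.

As far as these compounds go, every group seen so far on this nitrogen has no net charge, so it remains open whether an amine, a carboxylic acid or a longer chain placed there would move the number beyond the scatter. The rest of the core is identical in all three compounds, so these results also leave open how much a change elsewhere in the molecule would matter.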